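Estimating compound 4 from an unmeasured neighbour

The source may report more compounds than this note shows. Statements on the series, on what has been measured and on what is new or still open speak of the compounds shown alone.

- Compound 1 `O=C(NCc1ccc(S(=O)(=O)c2ccccc2)cc1)c1cc(-c2cccnc2)no1` gives 66%
- Compound 2 `O=C(NCc1ccc(S(=O)(=O)N2CCCCC2)cc1)c1ccn2ccnc2c1` gives "not determined" (no result reported)
- Compound 3 `O=C(NCc1ccc(S(=O)(=O)c2ccccc2)cc1)c1cc2cnccc2[nH]1` gives 54%

These results come from an ADME assay on microsomes from liver (Mus musculus) for metabolic stability, read by LC-MS, with a stated time of 30 min, tested at 1 uM (on this read-out higher numbers stand for a more stable compound and lower numbers for a less stable compound), and leave compound 2 with no number ("not determined" (no result reported)), so it offers no starting level. Compound 4 `O=C(NCc1ccc(S(=O)(=O)N2CCCCC2)cc1)c1cc2ccncc2o1` has not yet been measured. The structural change is a group of 9 heavy atoms (7 carbon, 1 nitrogen, 1 oxygen; one five-membered aromatic ring with 1 hetero atom, one six-membered aromatic ring with 1 hetero atom) in place of a group of 9 heavy atoms (7 carbon, 2 nitrogen; one five-membered aromatic ring with 2 hetero atoms, one six-membered aromatic ring with 1 hetero atom), on a carbonyl carbon and it leaves the hydrogen-bond donor and acceptor counts unchanged. Going by the values given here, no measured step shows what such a change does, so none beyond the scatter is expected, in either direction. The estimate therefore rests on the level of compound 1 (66%) and compound 3 (54%), with a wide range. Compound 4 is expected at 52% (estimated range 27% to 77%).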

Compound 4, percent of the compound remaining: 0.14%
For compound 4 the middle estimate is 51.9 percentage points above the measured one, outside the stated range (below it).
By their numbers in this assay, from the lowest: compound 4; then compound 3; then compound 1.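

No step can be read between compound 2, which carries no number, and compound 4. The compounds shown leave open what the exchange on the carbonyl carbon does in this assay, and nothing shown bears on a cause.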